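Acyl variation on the trimethoxyphenyl tertiary amide

The source may hold more compounds than are shown below. What is called first, only, known or untested is meant among the compounds shown, and "the series" means these compounds.

Compound 1 `COc1ccc(CN(C(=O)C2CC2)c2cc(OC)c(OC)c(OC)c2)cc1O` carries a cyclopropylcarbonyl on the amide-type nitrogen. In a functional assay on KYSE-450 cells (Homo sapiens) for inhibition, read by MTT assay, with a stated time of 48 h (on this read-out lower numbers stand for stronger inhibition and higher numbers for weaker inhibition), compound 1 gives 80 nM, the lowest of the two numbers in hand. The secondary amine compound 2 `COc1ccc(CNc2cc(OC)c(OC)c(OC)c2)cc1` gives 4890 nM in this assay. Compound 3 `COc1cc(NCc2ccccc2)cc(OC)c1OC`, lacking the methoxy on the benzyl ring, reaches only the assay limit of > 80000 nM in this assay, which is a limit and not a number. Among the measured compounds shown here, the step of an at least 16-fold higher number from compound 2 to compound 3 (1.21 log units; beyond the scatter) is the single measured step, and it concerns the methoxy on an aromatic carbon, sitting at the limit of > 80000 nM in this assay, at which 1 of the 3 values shown sits.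

Compound 4 `COc1ccc(CN(C(=O)C(C)Br)c2cc(OC)c(OC)c(OC)c2)cc1O` differs from compound 1 by 1-bromoethyl in place of cyclopropyl on a carbonyl carbon. For the measured compounds named here, no measured step touches the acyl group; the measured step lies elsewhere on the scaffold and does not bear on this change. With no guidance from the series, the step is expected to be small, and for compound 4 the expected step is a 1.9-fold higher number from compound 1 to compound 4 (0.27 log units; within the scatter), within or near the scatter. Compound 4 is therefore estimated at 150 nM, with a range from 40 nM to 600 nM.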

Compound 4, half-maximal inhibitory concentration: 160 nM
Beside the measured number, compound 4's estimate is 1.1-fold (0.03 log units) below it; the measured number falls inside the stated range.
By their numbers in this assay, from the lowest: compounds 1 and 4 (each within the scatter of the next); then compound 2. At a limit, above all of these: compound 3.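

In this assay the acyl position now has its first measured change: a 2.0-fold higher number from compound 1 to compound 4 (0.30 log units; within the scatter). Replacing cyclopropyl with 1-bromoethyl on this carbonyl carbon therefore leaves the read-out within the scatter, so compound 1 and compound 4 cannot be separated, and the three-membered ring is not needed to hold activity in this pair. Nothing in the data shown accounts for this step.

Still open, from the compounds shown here alone, is how an amine, a carboxylic acid or a longer alkyl chain in place of cyclopropyl on the carbonyl carbon would read out in this assay. Compound 2 differs from compound 1 in more than one place, so the contribution of the acyl group itself to the difference between their values cannot be read from these compounds.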